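A few compounds are considered here, and "the series" means these few. Any claim that something is new, unique, unknown or untested is made for them only; others in the source may bear on it.

Compound 1, with the structure `CCOc1ccc([C@@H]2CC(=O)c3cc(CC=C(C)C)c(OC)cc3O2)cc1`, was tested in a functional assay on A549 cells (Homo sapiens) for inhibition, read by sulforhodamine B assay, with a stated time of 48 h, tested at 50 uM (on this read-out lower numbers stand for less inhibition of growth and higher numbers for more inhibition of growth at the one concentration tested), where compound 1 gives 37%. Two related compounds share its core. Compound 2, `C#CCO/N=C1/C[C@@H](c2ccc(OC)cc2)Oc2cc(OC)c(CC=C(C)C)cc21`, gives 64% in this assay, a number beyond the usual scatter above that of compound 1. Compound 3, `COc1ccc([C@@H]2C/C(=N/OCc3cn(-c4ccc(NC(=O)c5ccccc5)cc4)nn3)c3cc(CC=C(C)C)c(OC)cc3O2)cc1`, gives 31% in this assay, which lies within the usual scatter of the number for compound 1, so the two cannot be told apart. Among these three, compound 1 thus stands in the middle of the range, separated clearly only from compound 2.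

Compound 4, `COc1cc2c(cc1CC=C(C)C)C(=O)C[C@@H](c1ccc(Oc3ccc(Br)cc3)cc1)O2`, has not yet been measured. It differs from compound 1 in one place: 4-bromophenyl in place of ethyl on an oxygen on an aromatic ring. Going by the values given here, no pair of measured compounds here shows what such a change does, so the expectation rests on the spread seen so far. The change swaps a small chain for a larger ring bearing bromine on the same oxygen, and the estimated step is a number 5 percentage points higher from compound 1 to compound 4 (within the scatter), expected to be small and of uncertain direction, possibly none beyond the scatter. Compound 4 is therefore expected to give about 42% in this assay, within a range from 20% to 65%.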

Compound 4, percent growth inhibition at one concentration: 72%
Estimate against measurement, compound 4: 30 percentage points below; measured number outside the range, above it.
By their numbers in this assay, from the lowest: compounds 3 and 1 (each within the scatter of the next); then compounds 2 and 4 (each within the scatter of the next).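

Putting 4-bromophenyl in place of ethyl on an oxygen on an aromatic ring gives a number 35 percentage points higher from compound 1 to compound 4 (beyond the scatter) in this assay, the first clear effect in this set that can be traced to a single place on the shared core. The earlier compounds shown here differ from one another in more than one place, so they could not show what this oxygen substituent alone does; this pair shows that the position accepts a far larger group than ethyl with no loss of growth inhibition, and with a clear gain at the one concentration tested. The data at hand offer no explanation for this rise.

The ring and the bromine entered together, so this single step cannot say which of them matters: plain phenyl on the same oxygen would separate the two, and a longer chain such as butyl would show whether a ring is needed at all. On these data alone, it also remains open how compound 4 behaves at other concentrations or on other cells, as one number at one concentration gives no full dose response.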